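The source may hold more compounds than are shown below. What is called first, only, known or untested is meant among the compounds shown, and "the series" means these compounds.

Measured so far in a physicochemical assay for solubility, read by HPLC, in phosphate buffer, measured as kinetic solubility, at pH 7.4; on this read-out lower numbers stand for lower solubility and higher numbers for higher solubility: compound 1 `CCOC(=O)c1cc(-c2ccc(Cl)cc2)n(-c2ccc(S(N)(=O)=O)cc2)c1C` gives 4200 nM; compound 2 `CCOC(=O)c1cc(-c2ccc(Cl)cc2)n(-c2ccc(S(N)(=O)=O)cc2)c1N` gives 4400 nM; compound 3 `NS(=O)(=O)c1ccc(-c2cc(C(=O)C3CC3)nn2-c2ccc(Cl)cc2)cc1` gives 25600 nM.

Compound 3 stands highest of the three numbers in this assay, with compound 2 nearest and compound 1 furthest, both gaps beyond the scatter. Compound 4 `NS(=O)(=O)c1ccc(-c2cc(C(=O)NN3CCCCC3)nn2-c2ccc(Cl)cc2)cc1` differs from compound 3 by (piperidin-1-yl)amino in place of cyclopropyl on a carbonyl carbon. Going by the values given here, the only measured single step, a 1.0-fold higher number from compound 1 to compound 2 (0.02 log units; within the scatter), sits on the core of compound 1 and at an aromatic carbon, so no measured step bears directly on a change at a carbonyl carbon. With nothing to point either way, the step to compound 4 is expected to stay small, a 1.2-fold higher number from compound 3 to compound 4 (0.07 log units; within the scatter). Compound 4 is therefore estimated at 30000 nM, with a range from 10000 nM to 90000 nM.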

Compound 4, solubility: 53700 nM
The estimate for compound 4 lay 1.8-fold (0.25 log units) below the measured number; measured number inside the range.
By their numbers in this assay, from the lowest: compounds 1 and 2 (each within the scatter of the next); then compound 3; then compound 4.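

The carbonyl carbon is a place where the read-out can move in this assay: (piperidin-1-yl)amino in place of cyclopropyl gives a 2.1-fold higher number from compound 3 to compound 4 (0.32 log units; beyond the scatter) in a change that also adds a hydrogen-bond donor and a six-membered ring with a hetero atom. Going by these compounds alone, the only earlier single step lay at an aromatic carbon on the core of compound 1 and stayed within the scatter.

Going by these compounds, whether the ring or the amide hydrogen carries the step remains open, as does the outcome with a cyclohexyl or dimethylamino group on the same carbonyl carbon. Nothing measured here gives a cause for the step.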